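The source may report more compounds than this note shows. Statements on the series, on what has been measured and on what is new or still open speak of the compounds shown alone.

Values in a functional assay on Shh Light II cells (Mus musculus) for inhibition, read by a luciferase reporter; on this read-out higher numbers stand for weaker inhibition and lower numbers for stronger inhibition
compound 1 `C[C@@H]1C[C@H](c2nc(-c3ccc4ccccc4n3)no2)CCN1C(=O)Nc1ccccc1Cl` gives 2400 nM
compound 2 `O=C(NCC1CCC1)N1CCC(c2nc(-c3ccc4ccccc4n3)no2)CC1` gives 410 nM

Compound 2 carries the lower number of the two (410 nM), which makes it the stronger inhibitor of this pair, and its gap to compound 1 lies beyond the scatter. Within the data shown here, the two compounds differ in more than one place, so no single-change step is available yet.

Compound 3 `O=C(Nc1cccc2cccnc12)N1CCC(c2nc(-c3ccc4ccccc4n3)no2)CC1` keeps the rest of compound 2 and changes one group, with quinolin-8-yl in place of cyclobutylmethyl on an amide-type nitrogen. Among the measured compounds shown here, no measured compound carries quinolin-8-yl, so the data give no direction for this change. The expectation in this assay is therefore no step beyond the scatter (a 1.0-fold lower number from compound 2 to compound 3 (0.01 log units; within the scatter)), though the uncertainty is wide. For the measured compounds named here, the upper end of the expected range is set by the only other measured number, that of compound 1 (2400 nM). Compound 3 is estimated at 400 nM (expected range 80 nM to 2400 nM).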

Compound 3, half-maximal inhibitory concentration: 1400 nM
Compound 3: the middle estimate sits 3.5-fold (0.54 log units) below what was measured; measured number inside the range.
By their numbers in this assay, from the lowest: compound 2; then compounds 3 and 1 (each within the scatter of the next).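

In this assay, the series now has its first single-change step: quinolin-8-yl in place of cyclobutylmethyl on an amide-type nitrogen gives a 3.4-fold higher number from compound 2 to compound 3 (0.53 log units; beyond the scatter). This shows that the group at this position alters the read-out while the rest of compound 2 stays fixed, although the step is modest and compound 3 retains measurable inhibition. The change replaces a four-membered non-aromatic carbon ring with two fused six-membered aromatic rings, and it also adds heavy atoms and a hydrogen-bond acceptor, so this one step cannot separate these differences. No measurement available here accounts for the step.

Naphthalen-1-yl at the same place would test the ring nitrogen of quinolin-8-yl, while phenyl, cyclopropylmethyl or a straight butyl chain would show how the read-out follows the size and type of the group. Compound 1 differs from compound 2 and compound 3 in more than one place, so its contribution to this question cannot be read.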